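Amide substituent change from compound 3 to compound 4

The source may hold more compounds than are shown below. What is called first, only, known or untested is meant among the compounds shown, and "the series" means these compounds.

Compound 1 `CCn1c(C(=O)N[C@@H](C)C(=O)OC)ccc1C(CC)(CC)c1ccc(OCS(=O)(=O)c2ccccc2)c(C)c1`: 43700 nM
Compound 2 `CCn1c(C(=O)N[C@@H](CC(=O)OC)C(=O)OC)ccc1C(CC)(CC)c1ccc(OCS(=O)(=O)c2ccccc2)c(C)c1`: > 50000 nM, a limit of the assay and not a number
Compound 3 `CCN(CC)CCNC(=O)c1ccc(C(CC)(CC)c2ccc(OCS(=O)(=O)c3ccccc3)c(C)c2)n1CC`: 4680 nM

Compound 3 gives the lowest number in a functional assay on MCF7 cells (Homo sapiens) for antiproliferative activity, read by MTT assay, with a stated time of 24 h (on this read-out lower numbers stand for stronger inhibition and higher numbers for weaker inhibition), at 4680 nM. Compound 4 `CCn1c(C(=O)NC2(CO)CC2)ccc1C(CC)(CC)c1ccc(OCS(=O)(=O)c2ccccc2)c(C)c1` carries 1-(hydroxymethyl)cyclopropyl in place of 2-(diethylamino)ethyl on an amide-type nitrogen. Going by the values given here, the steps that bear on this are a 9.3-fold lower number from compound 1 to compound 3 (0.97 log units; beyond the scatter) and an at least 10-fold lower number from compound 2 to compound 3 (1.02 log units; beyond the scatter), each bringing in 2-(diethylamino)ethyl and each lowering the number. As far as these compounds go, the entering group itself is untested. Taking 2-(diethylamino)ethyl away is therefore expected to raise the number by a modest step of similar size. The expected step is a 4.7-fold higher number from compound 3 to compound 4 (0.67 log units; beyond the scatter). The estimate for compound 4 is 22000 nM, with an expected range of 8000 nM to 50000 nM.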

Compound 4, half-maximal inhibitory concentration: 28800 nM
Estimate against measurement, compound 4: 1.3-fold (0.12 log units) below; low and high end bracket the measured number.
By their numbers in this assay, from the lowest: compound 3; then compounds 4 and 1 (each within the scatter of the next). At a limit, above all of these: compound 2.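

In this assay, 1-(hydroxymethyl)cyclopropyl on the amide-type nitrogen does not keep the lower number seen with 2-(diethylamino)ethyl, giving a 6.2-fold higher number from compound 3 to compound 4 (0.79 log units; beyond the scatter), while the comparison with the 1-(methoxycarbonyl)ethyl amide gives a 1.5-fold lower number from compound 1 to compound 4 (0.18 log units; within the scatter). Compound 2 stands at a limit of the assay, not a number: the limit of > 50000 nM in this assay, at which 1 of the 4 values shown sits. Against that limit the reading is only a floor, an at least 1.7-fold lower number from compound 2 to compound 4 (0.23 log units; that floor lies within the scatter).

Still open, as far as these compounds go, is whether the lower number of compound 3 depends on the diethylamino nitrogen or on the ethyl chain that carries it. A 2-(dimethylamino)ethyl group, a 2-morpholinoethyl group or a 3-(diethylamino)propyl chain at this position would test this.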